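A few compounds are considered here, and "the series" means these few. Any claim that something is new, unique, unknown or untested is made for them only; others in the source may bear on it.

In a functional assay on A549 cells (Homo sapiens) for inhibition, read by MTT assay, with a stated time of 72 h (on this read-out lower numbers stand for stronger inhibition and higher numbers for weaker inhibition), two compounds have been measured so far. Compound 1 `COc1cc(N(C)CCN(C)C)c(NC(=O)C=C(C)C)cc1Nc1nc2c(c(-c3cn(C)c4ccc(F)cc34)n1)CSCC2` gives 902 nM, and compound 2 `C/C=C\C(=O)Nc1cc(Nc2nc3c(c(-c4cn(C)c5ccc(F)cc45)n2)CSCC3)c(OC)cc1N(C)CCN(C)C` gives 5310 nM, the higher of the two numbers and so the weaker inhibition. Compound 3 `C/C=C\C(=O)Nc1cc(Nc2nc3c(c(-c4cn(C)c5ccccc45)n2)CSCC3)c(OC)cc1N(C)CCN(C)C` keeps the prop-1-en-1-yl group of compound 2 on the carbonyl carbon and differs elsewhere: hydrogen in place of fluoro on an aromatic carbon. Hydrogen thus stands in place of fluoro on an aromatic carbon, which turns 5-fluoro-1-methyl-1H-indol-3-yl into 1-methyl-1H-indol-3-yl.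

For the measured compounds named here, the only measured step is a 5.9-fold higher number from compound 1 to compound 2 (0.77 log units; beyond the scatter). It comes from prop-1-en-1-yl in place of 2-methylprop-1-en-1-yl on a carbonyl carbon, so it bears only indirectly on the new change. Going by the values given here, no measured step removes or adds the fluoro, which leaves the data silent on its size or direction. No step beyond the scatter is therefore expected in this assay, although the range has to stay wide in both directions. The estimated step is a 1.1-fold lower number from compound 2 to compound 3 (0.03 log units; within the scatter). Compound 3 is expected at 5000 nM, with an estimated range from 2200 nM to 11000 nM.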

Compound 3, half-maximal inhibitory concentration: 6860 nM
Compound 3: the middle estimate sits 1.4-fold (0.14 log units) below what was measured; low and high end bracket the measured number.
By their numbers in this assay, from the lowest: compound 1; then compounds 2 and 3 (each within the scatter of the next).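

In this assay, the exchange of fluoro for hydrogen on this aromatic carbon, which turns 5-fluoro-1-methyl-1H-indol-3-yl into 1-methyl-1H-indol-3-yl, gives a 1.3-fold higher number from compound 2 to compound 3 (0.11 log units; within the scatter) and so stays within the usual scatter of repeated measurements. For the compounds shown here, this is the first reading on this position, and it shows that, with prop-1-en-1-yl on the carbonyl carbon, the fluoro can give way to hydrogen without a step that can be told apart from that scatter, whereas the one earlier step, a 5.9-fold higher number from compound 1 to compound 2 (0.77 log units; beyond the scatter) and beyond the scatter, came from the group on the carbonyl carbon. Nothing available accounts for how little the number responds to this single-atom exchange.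

On these data alone, whether the same exchange would also stay within the scatter with 2-methylprop-1-en-1-yl on the carbonyl carbon, the group carried by compound 1, remains open, as it is read here only with prop-1-en-1-yl. Also open, as far as these compounds go, is whether a chloro, a methoxy or a nitrile on the same aromatic carbon would leave the number within the scatter or shift it in either direction.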